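The source may report more compounds than this note shows. Statements on the series, on what has been measured and on what is new or still open speak of the compounds shown alone.

Measured so far in a functional assay (aorta) with Oryctolagus cuniculus as the target; on this read-out lower numbers stand for stronger inhibition and higher numbers for weaker inhibition:
compound 1 `N#Cc1ccccc1Cn1nc(-c2ccc(CO)o2)c2ccccc21` gives 8700 nM
compound 2 `OCc1ccc(-c2nn(Cc3ccc(Cl)s3)c3ccccc23)o1` gives 7200 nM
compound 3 `CCCCc1cnc(-c2nn(Cc3ccccc3F)c3ncccc23)nc1N` gives 218000 nM

Compound 3 has the highest number of the three, so the weakest inhibition: compound 1 is nearest, and compound 2 furthest, both well beyond the scatter. Compound 4 `N#CCCCCCc1cnc(-c2nn(Cc3ccccc3F)c3ncccc23)nc1N` differs from compound 3 only in that (cyanomethyl in place of hydrogen on a saturated chain carbon, four bonds along the chain from an aromatic carbon). Going by the values given here, the one measured step, a 1.2-fold lower number from compound 1 to compound 2 (0.08 log units; within the scatter), swaps a ring on a chain carbon and says nothing about lengthening a chain in this way, so no measured step bears on this change. Compound 4 is therefore expected to show no step beyond the scatter, a 1.1-fold lower number from compound 3 to compound 4 (0.04 log units; within the scatter). Compound 4 is estimated at 200000 nM, within 70000 nM to 600000 nM.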

Compound 4, half-maximal inhibitory concentration: 588000 nM
Beside the measured number, compound 4's estimate is 2.9-fold (0.47 log units) below it, within the range that was stated.
By their numbers in this assay, from the lowest: compounds 2 and 1 (each within the scatter of the next); then compound 3; then compound 4.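

In this assay, this chain tolerates extension poorly: cyanomethyl in place of hydrogen on a saturated chain carbon, four bonds along the chain from an aromatic carbon, gives a modest weakening of inhibition, a 2.7-fold higher number from compound 3 to compound 4 (0.43 log units; beyond the scatter). Going by these compounds alone, this is the first measured effect of changing this chain, since the earlier step concerned a different part of the molecule. Nothing available explains the weakening. Still open, from the compounds shown here alone, is whether it follows from the nitrile or from the added chain length. A longer plain carbon chain, or an amine in place of the nitrile, would separate the two.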